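From compound 2 to compound 3: one added group

The compounds below may be only part of what the source reports. "The series", "measured", "known", "first", "only" and "open" are said of these compounds alone.

Values measured in an ADME assay on BaF3 cells (Mus musculus) for antiproliferative activity, read by CCK-8 assay, with a stated time of 72 h (on this read-out higher numbers stand for weaker inhibition of growth and lower numbers for stronger inhibition of growth), so far:
compound 1 `CN1CCN(Cc2ccc(NC(=O)CCSc3ccc4c(/C=C/c5ccccn5)n[nH]c4c3)cc2C(F)(F)F)CC1` gives 2480 nM
compound 2 `O=C(NCCCSc1ccc2c(/C=C/c3ccccn3)n[nH]c2c1)c1cccc(C(F)(F)F)c1` gives 980 nM

In this assay compound 2 stands lowest of the two at 980 nM and compound 1 stands higher, a gap beyond the scatter. Compound 3 `CN1CCN(Cc2ccc(C(=O)NCCCSc3ccc4c(/C=C/c5ccccn5)n[nH]c4c3)cc2C(F)(F)F)CC1` has (4-methylpiperazin-1-yl)methyl in place of hydrogen on an aromatic carbon of compound 2, ortho to a trifluoromethyl group ((4-methylpiperazin-1-yl)methyl in place of hydrogen on an aromatic carbon). Among the measured compounds shown here, no step between measured compounds isolates this change. For the measured compounds named here, the only measured compound carrying this group is compound 1 at 2480 nM and it also differs from compound 2 elsewhere, so it offers weak guidance. A slight move toward a higher number is expected in this assay and should stay within the scatter. The estimated size is a 1.3-fold higher number from compound 2 to compound 3 (0.12 log units; within the scatter) on this thin evidence. The expected value for compound 3 is 1300 nM with an estimated range from 350 nM to 4000 nM in this read-out.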

Compound 3, concentration for 50% growth inhibition: 4400 nM
Compound 3: the middle estimate sits 3.4-fold (0.53 log units) below what was measured; measured number above the stated range.
By their numbers in this assay, from the lowest: compound 2; then compounds 1 and 3 (each within the scatter of the next).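

In this assay, among the compounds shown here, the addition of (4-methylpiperazin-1-yl)methyl in place of hydrogen on an aromatic carbon, ortho to a trifluoromethyl group and para to a large group, gives a 4.5-fold higher number from compound 2 to compound 3 (0.65 log units; beyond the scatter) as the first step that isolates this change. At this position, in this single pair, the added group therefore goes with weaker inhibition of growth, by a margin beyond the scatter. No supporting measurement bears on the reason for this step.

The compounds shown leave open whether the step follows from the whole added group or only from its ring, and whether a morpholin-4-ylmethyl or dimethylaminomethyl group on the same carbon would give a step of similar size. They also leave open whether the step persists when a chlorine replaces the trifluoromethyl group.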